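Shifting methyl groups on the phenyl ring of a pyranone core

This account rests on a few compounds, and the source may have more. Where it says the series, first, only, none or still open, it means among the compounds named here.

Compound 1 `CC1=C(O)C(C)(C)c2oc(-c3ccccc3)cc(=O)c2C1=O` in a functional assay on KB cells (Homo sapiens) for cytotoxicity, read by sulforhodamine B assay (on this read-out higher numbers stand for an effect only at larger amounts of compound and lower numbers for an effect already at smaller amounts), reaches only the limit of the assay, > 40 ug/mL.
Compound 2 `CC1=C(O)c2c(oc(-c3ccc(C)cc3)cc2=O)C(C)(C)C1=O` gives 22.5 ug/mL in this assay.
Compound 3 `CC1=C(O)c2c(oc(-c3ccccc3C)cc2=O)C(C)(C)C1=O` gives 37.3 ug/mL in this assay.

Compounds 2 and 3 share one core and differ only in where a methyl sits on the phenyl ring; a 1.7-fold higher number from compound 2 to compound 3 (0.22 log units; within the scatter). Compound 3 therefore stands within the scatter of compound 2, while compound 1 is known only as a limit (the limit of > 40 ug/mL in this assay, at which 1 of the 3 values shown sits).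

Compound 4 `CC1=C(O)c2c(oc(-c3cc(C)cc(C)c3)cc2=O)C(C)(C)C1=O` differs from compound 3 by 3,5-dimethylphenyl in place of 2-methylphenyl on an aromatic carbon. Among the compounds with values here, the single measured step that bears on this is the one from compound 2 to compound 3, which moved a methyl and stayed within the scatter; a second methyl on the ring is not covered by any measured pair. The expected step is therefore a 1.2-fold lower number from compound 3 to compound 4 (0.07 log units; within the scatter), none beyond the scatter. Compound 4 is estimated at 32 ug/mL, between 14 ug/mL and 60 ug/mL.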

Compound 4, concentration for half-maximal effect: 53.1 ug/mL
For compound 4 the middle estimate is 1.7-fold (0.22 log units) below the measured one; the measured number falls inside the stated range.
By their numbers in this assay, from the lowest: compounds 2, 3 and 4 (each within the scatter of the next, the first and the last beyond it).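

In this assay, at the aromatic carbon next to the ring oxygen, the swap to 3,5-dimethylphenyl gives a 1.4-fold higher number from compound 3 to compound 4 (0.15 log units; within the scatter), so it cannot be told apart from 2-methylphenyl. The series now also holds its first step beyond the scatter, a modest one: a 2.4-fold higher number from compound 2 to compound 4 (0.37 log units; beyond the scatter). Nothing measured here explains that step.

Still open, going by these compounds, is how an amine or a carboxylic acid on the phenyl ring, or an ethyl or longer chain in place of methyl, would read in this assay. Whether any such group would give a lower number than compound 2 is also unknown.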